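From compound 3 to compound 4: one aromatic group swapped

The source may hold more compounds than are shown below. What is called first, only, known or untested is meant among the compounds shown, and "the series" means these compounds.

Measured in a functional assay on DU-145 cells (Homo sapiens) for inhibition, read by trypan blue exclusion, with a stated time of 96 h; on this read-out lower numbers stand for stronger inhibition of growth and higher numbers for weaker inhibition of growth:
compound 1 `O=C(/C(=C\c1ccc(Cl)cc1)S(=O)(=O)c1ccc(Br)cc1)c1ccc(Br)cc1` gives 50000 nM
compound 2 `COc1ccc(/C=C(\C(=O)c2ccc(Br)cc2)S(=O)(=O)c2ccc(Br)cc2)c(F)c1` gives 10000 nM
compound 3 `O=C(/C(=C\c1ccc(Cl)c([N+](=O)[O-])c1)S(=O)(=O)c1ccc(Br)cc1)c1ccc(Br)cc1` gives 10000 nM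

Compound 3 stands level with compound 2, as no change at the digits printed from compound 2 to compound 3 (within the scatter) shows, and the two share the lowest number of the set. Compound 4 `O=C(/C(=C\c1ccc(F)cc1F)S(=O)(=O)c1ccc(Br)cc1)c1ccc(Br)cc1` carries 2,4-difluorophenyl in place of 4-chloro-3-nitrophenyl on a double-bonded chain carbon bound to a double-bonded chain carbon, and the counted difference is 2,4-difluorophenyl in place of 4-chloro-3-nitrophenyl on a double-bonded chain carbon bound to a double-bonded chain carbon with the rest of the core unchanged.

Two modest steps bear on this place. Putting 2-fluoro-4-methoxyphenyl in place of 4-chlorophenyl gave a 5.0-fold lower number from compound 1 to compound 2 (0.70 log units; beyond the scatter) and adding nitro gave a 5.0-fold lower number from compound 1 to compound 3 (0.70 log units; beyond the scatter) in the same series. Compound 4 has no nitro group but, like compound 2 at 10000 nM, it carries fluorine, so in this assay a small move toward a higher number is expected, probably within the scatter. The estimated step is a 1.5-fold higher number from compound 3 to compound 4 (0.18 log units; within the scatter) on this reasoning. For compound 4 the estimated value is 15000 nM with an expected range of 5000 nM to 50000 nM in this test.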

Compound 4, concentration for 50% growth inhibition: 7500 nM
For compound 4 the middle estimate is 2.0-fold (0.30 log units) above the measured one; measured number inside the range.
By their numbers in this assay, from the lowest: compounds 4, 2 and 3 (each within the scatter of the next); then compound 1.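

In this assay, the step from the 4-chloro-3-nitrophenyl ring to the 2,4-difluorophenyl ring is a 1.3-fold lower number from compound 3 to compound 4 (0.12 log units; within the scatter), so a nitro group is not required at this position to stay level with the best numbers in the set. Fluoro in place of methoxy gives a 1.3-fold lower number from compound 2 to compound 4 (0.12 log units; within the scatter), so the same holds for the methoxy group. The step of a 6.7-fold lower number from compound 1 to compound 4 (0.82 log units; beyond the scatter) places a third, different ring clear of the 4-chlorophenyl ring, leaving compound 1 alone apart from the other three, and nothing available explains this difference.

From the compounds shown here alone, it remains open whether an amine or a carboxylic acid on this aromatic ring would keep the number level with these three or shift it. Going by these compounds, the effect of changing either of the two 4-bromophenyl groups, which stay fixed throughout, also remains open.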